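This account rests on a few compounds, and the source may have more. Where it says the series, first, only, none or still open, it means among the compounds named here.

Measured so far:
compound 1, `CC(=O)Oc1ccccc1C(=O)O[C@H]1CO[C@H]2[C@@H]1OC[C@H]2OC(=O)c1ccccc1`: 0.0107 h
compound 2, `CC(=O)Oc1ccccc1C(=O)O[C@H]1CO[C@H]2[C@@H]1OC[C@H]2OC(=O)c1cccnc1`: 0.00617 h

For the measured compounds named here, in an ADME assay on a cell-free system (plasma, Homo sapiens) for metabolic stability, with Plasma (Rattus norvegicus) as the target, read by HPLC, at pH 7.4 (a lower number here means that the compound disappears faster, a higher number that the compound lasts longer), compound 2 gives 0.00617 h, the lowest of the two numbers so far. Its nearest neighbour is compound 1, which gives 0.0107 h in this assay, and the step of a 1.7-fold lower number from compound 1 to compound 2 (0.24 log units; within the scatter) lies within the scatter, so the two compounds cannot be told apart on these numbers. Compound 3, `CC(=O)Oc1ccccc1C(=O)O[C@H]1CO[C@H]2[C@@H]1OC[C@H]2OC(=O)c1ccc(CO[N+](=O)[O-])cc1`, has not yet been measured. It differs from compound 2 in one place: 4-((nitrooxy)methyl)phenyl in place of pyridin-3-yl on a carbonyl carbon. Going by the values given here, only one measured step bears on this change, a 1.7-fold lower number from compound 1 to compound 2 (0.24 log units; within the scatter), which exchanged phenyl for pyridin-3-yl on the same carbonyl carbon and stayed within the scatter. Among the compounds with values here, compound 3 goes back to an aromatic ring of carbon only, now as 4-((nitrooxy)methyl)phenyl, a group no measured pair covers directly. The expectation is therefore a small step, a 1.5-fold higher number from compound 2 to compound 3 (0.16 log units; within the scatter), not clearly beyond the scatter. For compound 3 in this assay the estimated half-life is 0.009 h, with a range from 0.004 h to 0.02 h.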

Compound 3, half-life: 0.04 h
Compound 3: the middle estimate sits 4.4-fold (0.65 log units) below what was measured; measured number outside the range, above it.
By their numbers in this assay, from the lowest: compounds 2 and 1 (each within the scatter of the next); then compound 3.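

Replacing the group on this carbonyl carbon can shift the half-life in this assay clearly: 4-((nitrooxy)methyl)phenyl in place of pyridin-3-yl gives a 6.5-fold higher number from compound 2 to compound 3 (0.81 log units; beyond the scatter), whereas the earlier exchange of phenyl for pyridin-3-yl stayed within the scatter. For the compounds shown here, the tighter comparison changes less, placing (nitrooxy)methyl in place of hydrogen on an aromatic carbon, and it gives a 3.7-fold higher number from compound 1 to compound 3 (0.57 log units; beyond the scatter), so the rise also appears when the ring stays one of carbon only and only this group is added. Nothing available here accounts for why the compound with this added group lasts longer in this assay.

Going by these compounds, whether the nitrooxy end itself matters, or whether any group on that aromatic carbon would give a similar rise, remains open, and a plain methyl or a hydroxymethyl group at the same place would help separate the two. On these data alone, how a longer chain carrying the nitrooxy end, or an amine in its place, would behave also remains open, so these compounds cannot show how far the rise extends.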